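The compounds below may be only part of what the source reports. "The series", "measured", "known", "first", "only" and "open" are said of these compounds alone.

All three measured compounds share one core and differ only in the group carried by the sulfonyl sulfur. Compound 1 `Cc1ccc(S(=O)(=O)Nc2ccc(-c3nc4ccccc4o3)cc2)cc1` carries a 4-methylphenyl there. In an assay on cells for inhibition of HSP60/HSP10 (Homo sapiens), with a stated time of 60 min (on this read-out higher numbers stand for weaker inhibition and lower numbers for stronger inhibition), compound 1 gives only a limit of the assay, > 100000 nM. Compound 2 `O=S(=O)(Nc1ccc(-c2nc3ccccc3o2)cc1)c1cccc(O)c1` carries a 3-hydroxyphenyl instead, and in this assay compound 2 gives 62000 nM. Compound 3 `CS(=O)(=O)Nc1ccc(-c2nc3ccccc3o2)cc1` carries a plain methyl. In this assay compound 3 gives only a limit of the assay, > 100000 nM. Compound 3 thus sits at the limit of the assay, as does compound 1. The step from 4-methylphenyl to methyl reads a step that the two limits leave unreadable from compound 1 to compound 3, and the step from 3-hydroxyphenyl to methyl reads an at least 1.6-fold higher number from compound 2 to compound 3 (0.20 log units; that floor lies within the scatter). Compound 4 `O=S(=O)(Nc1ccc(-c2nc3ccccc3o2)cc1)c1cccs1` is the next compound, and it differs from compound 3 in one place: thiophen-2-yl in place of methyl on a sulfonyl sulfur. The measured steps bear on this change only loosely, because of the limit of > 100000 nM in this assay, at which 2 of the 3 values shown sit, so the size of most moves at this position cannot be read from them. A thiophen-2-yl ring is closer in kind to the 4-methylphenyl of compound 1 than to the 3-hydroxyphenyl of compound 2, and the step expected from compound 3 to compound 4 is therefore a number no higher from compound 3 to compound 4 (the limit leaves the size open), none beyond the scatter. For compound 4 the expected value in this assay is 100000 nM, within a range from 40000 nM to 300000 nM.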

Compound 4, half-maximal inhibitory concentration: 63000 nM
For compound 4 the middle estimate is 1.6-fold (0.20 log units) above the measured one; low and high end bracket the measured number.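

Thiophen-2-yl gives a measured number rather than a limit of the assay in this assay, yet the step from methyl reads only an at least 1.5-fold lower number from compound 3 to compound 4 (0.20 log units; that floor lies within the scatter), and the step from 4-methylphenyl reads an at least 1.5-fold lower number from compound 1 to compound 4 (0.20 log units; that floor lies within the scatter). The comparison with 3-hydroxyphenyl reads a 1.0-fold higher number from compound 2 to compound 4 (0.01 log units; within the scatter), so these two rings cannot be told apart here, and a measured number at this position does not require the hydroxyl group carried by compound 2. A ring on the sulfonyl sulfur is still no guarantee of a measured number, as the 4-methylphenyl of compound 1 goes against that pattern, and the true size of the steps that start from a limit stays hidden for one plain reason: the limit of > 100000 nM in this assay, at which 2 of the 4 values shown sit.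

Going by these compounds, what remains open is whether any group on the sulfonyl sulfur can bring the number clearly beyond the scatter of the values seen so far. A longer alkyl chain in place of methyl, or a ring bearing an amine or a carboxylic acid, could show whether this position tolerates only modest variation or can move the read-out much further.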